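A few compounds are considered here, and "the series" means these few. Any claim that something is new, unique, unknown or untested is made for them only; others in the source may bear on it.

Measured so far:
- compound 1 `Cc1nc(N)nc(N[C@@H]2C[C@H](CO)[C@@H](O)[C@H]2O)c1-c1nc2ccccc2s1` gives 4000 nM in an ADME assay on cells (Homo sapiens) for cytotoxicity, read by polymerase chain reaction, with a stated time of 3 days; a higher number here means that more compound is tolerated, a lower number that less compound is tolerated
- compound 2 `Cc1nc(NCC2CCC2)nc(N[C@@H]2C[C@H](CO)[C@@H](O)[C@H]2O)c1-c1nc2ccccc2s1` gives > 25000 nM in this assay

For compound 2 this is a limit of the assay, not a number: compound 2 sits at the limit of > 25000 nM in this assay, at which 1 of the 2 values shown sits. Among the compounds with values here, the one measured step, an at least 6.2-fold higher number from compound 1 to compound 2 (0.79 log units; beyond the scatter), came with the addition of a chain on the ring nitrogen.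

Compound 3 `COCCNc1nc(C)c(-c2nc3ccccc3s2)c(N[C@@H]2C[C@H](CO)[C@@H](O)[C@H]2O)n1` keeps that chain but changes its outer part: methoxymethyl in place of cyclobutyl on a saturated chain carbon bound to a nitrogen on an aromatic ring. Within the data shown here, no measured step covers this exchange, so the only guide is that compound 2 already lies at the limit with a chain in place. The change is expected to move the tolerated amount little, if at all, with an at least 1.2-fold lower number from compound 2 to compound 3 (0.09 log units; that floor lies within the scatter) as the estimate, and the assay may again report only a limit. Compound 3 is expected to give about 20000 nM, in the range 6000 nM to 50000 nM.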

Compound 3, half-maximal cytotoxic concentration: 21000 nM
The estimate for compound 3 lay 1.1-fold (0.02 log units) below the measured number; measured number inside the range.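

Compound 3 gives a measured number rather than a limit for a chain on this nitrogen in this assay, so the rise from replacing hydrogen can now be sized as a 5.3-fold higher number from compound 1 to compound 3 (0.72 log units; beyond the scatter), and it shows that a chain with no ring, such as 2-methoxyethyl, also goes the same way as cyclobutylmethyl. The exchange of cyclobutyl for methoxymethyl gives an at least 1.1-fold lower number from compound 2 to compound 3 (0.07 log units; that floor lies within the scatter), and that floor shows only a smallest possible size for this change. The entry for compound 2 is a limit, not a number: the limit of > 25000 nM in this assay, at which 1 of the 3 values shown sits.

As far as these compounds go, how much tolerated compound is lost in this exchange therefore stays open, including whether there is any real loss at all. Also open, from the compounds shown here alone, is whether a chain ending in an amine or a carboxylic acid, or a longer chain, would give a similar rise from compound 1.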